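Formyl Replaces Methyl in the Benzyl Series

This account rests on a few compounds, and the source may have more. Where it says the series, first, only, none or still open, it means among the compounds named here.

Compound 3 `Cc1cccc(-c2cn3ccnc3c(-c3ccc4ncn(Cc5ccccc5)c4c3)n2)c1` stands lowest of the three measured compounds in a functional assay on CCRF-CEM cells (Homo sapiens) for inhibition, read by sulforhodamine B assay, with a stated time of 48 h, tested at 10 uM (on this read-out higher numbers stand for more inhibition at the one concentration tested (going by the name of the read-out) and lower numbers for less inhibition), where compound 3 gives 21.1%. Its nearest neighbour is compound 2 `CCc1ccc(-c2cn3ccnc3c(-c3ccc4ncn(Cc5ccccc5)c4c3)n2)cc1`, which in this assay gives 49.7%; the furthest is compound 1 `O=Cc1ccc(-c2cn3ccnc3c(-c3ccc4ncn(C5CCCCC5)c4c3)n2)cc1`, which in this assay gives 77.9%. Compound 2 and compound 3 differ only in the aryl group on the shared core, and that exchange appears as a number 28.6 percentage points lower from compound 2 to compound 3 (beyond the scatter).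

Compound 4 `O=Cc1ccc(-c2cn3ccnc3c(-c3ccc4ncn(Cc5ccccc5)c4c3)n2)cc1` is the next step from compound 3: 4-formylphenyl in place of 3-methylphenyl on an aromatic carbon. Going by the values given here, no measured pair differs by exactly this exchange. Among the compounds with values here, the one step that bears on it is a number 28.6 percentage points lower from compound 2 to compound 3 (beyond the scatter), which shows that the group at this aromatic carbon of the six-membered ring with two nitrogens shifts the read-out by a modest amount beyond the scatter. The 4-formylphenyl group that enters is also carried by compound 1, which gives 77.9%, though compound 1 differs from compound 4 in its other substituent as well, so the two values of compound 1 and compound 4 cannot be separated into one change.

A rise beyond the scatter is therefore expected. Compound 4 is estimated at 60%, within a range of 35% to 85%. The step this estimate implies, a number 38.9 percentage points higher from compound 3 to compound 4 (beyond the scatter), is expected to run upward.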

Compound 4, a percentage reported as inhibition, at one concentration (the size of the read-out at that concentration, not a potency): 77.9%
The estimate for compound 4 lay 17.9 percentage points below the measured number; the measured number falls inside the stated range.
By their numbers in this assay, from the lowest: compound 3; then compound 2; then compounds 1 and 4 (each within the scatter of the next).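

Going by these compounds alone, with benzyl held on the aromatic nitrogen, 4-formylphenyl in place of 3-methylphenyl gives in this assay a number 56.8 percentage points higher from compound 3 to compound 4 (beyond the scatter) and so marks a large step at this aromatic carbon, where the only earlier step was modest. Formyl in place of ethyl gives a number 28.2 percentage points higher from compound 2 to compound 4 (beyond the scatter) and so places the 4-formylphenyl group above both other aryl groups in the benzyl series, with each of its two steps beyond the scatter. Within the data shown here, the other place reads differently in its single pair: with 4-formylphenyl held, benzyl in place of cyclohexyl on an aromatic nitrogen gives no change at the digits printed from compound 1 to compound 4 (within the scatter) and the read-out does not separate these two groups.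

Open, on these data alone, is whether the high number depends on the formyl group itself, which a carboxylic acid or a hydroxymethyl group on the same phenyl ring would test, and whether benzyl and cyclohexyl also match when the aryl group is 3-methylphenyl or 4-ethylphenyl. No measurement at hand accounts for the size of these steps.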